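Notes on the step from compound 3 to compound 4

The compounds below may be only part of what the source reports. "The series", "measured", "known", "first", "only" and "open" are said of these compounds alone.

Values so far in an ADME assay on HEK293 cells (Homo sapiens) for cytotoxicity, read by ATP content, with a stated time of 6 h; on this read-out lower numbers stand for higher toxicity in this test and higher numbers for lower toxicity in this test
compound 1 `CCCCNc1nc(N)nc2ccn(Cc3ccccn3)c12` gives > 24000 nM
compound 2 `Cc1nc(CNc2nc(N)nc3ccn(Cc4ccccn4)c23)cs1` gives > 24000 nM
compound 3 `Cc1cnc(CNc2nc(N)nc3ccn(Cc4ccccn4)c23)o1` gives > 24000 nM

Each of these values is a limit of the assay and not a number. Compound 3 gives > 24000 nM and this is a limit only. Going by the values given here, the series so far shares one position, namely the limit of > 24000 nM in this assay, at which 3 of the 3 values shown sit, and no ranking follows from it.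

Compound 4 `Cc1cc(CNc2nc(N)nc3ccn(Cc4ccccn4)c23)no1` differs from compound 3 by 5-methyl-1,2-oxazol-3-yl in place of 5-methyl-1,3-oxazol-2-yl on a saturated chain carbon bound to a nitrogen on an aromatic ring and the change is 5-methyl-1,2-oxazol-3-yl in place of 5-methyl-1,3-oxazol-2-yl on a saturated chain carbon bound to a nitrogen on an aromatic ring.

The closest measured swap is a step that the two limits leave unreadable from compound 2 to compound 3 and the other two are a step that the two limits leave unreadable from compound 1 to compound 2 and a step that the two limits leave unreadable from compound 1 to compound 3 so none of them gives a size to carry over. Resting on compound 3 and a step that the two limits leave unreadable from compound 2 to compound 3 no readable step and no direction can be expected in this assay from this change. The estimated step is a step that the limit leaves unreadable from compound 3 to compound 4 and it is expected to be no larger than the scatter. Compound 4 is expected near 30000 nM with an estimated range of 15000 nM to 60000 nM and a report as a limit is the likeliest outcome.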

Compound 4, half-maximal cytotoxic concentration: > 24000 nM
Compound 4: only a limit was reported (the forecaster's own chance of this, stated with the estimate: 85%); the middle value lies beyond the limit too.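

In this assay compound 4 gives > 24000 nM, which is a limit and not a number. No step from compound 1, compound 2 or compound 3 to compound 4 can be read: the limit of > 24000 nM in this assay, at which 4 of the 4 values shown sit.

The compounds shown leave open whether any of these groups on the saturated chain carbon changes the read-out at all.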